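The source may hold more compounds than are shown below. What is called first, only, known or untested is meant among the compounds shown, and "the series" means these compounds.

The measured compounds:

compound 1, `Nc1sc(-c2ccc(Cl)cc2)c(-c2ccc(Cl)cc2)c1C(=O)NC1CCC(O)CC1`, with 250 nM in a functional assay on A549 cells (Homo sapiens) for inhibition, read by sulforhodamine B assay, with a stated time of 72 h; a lower number here means a stronger inhibitor, a higher number a weaker inhibitor
compound 2, `COC(=O)c1c(N)sc(-c2ccc(Cl)cc2)c1-c1ccc(Cl)cc1`, with 5040 nM in this assay

Compound 2 stands at the highest of the two numbers recorded so far. Its nearest neighbour is compound 1, and the step between them, a 20-fold higher number from compound 1 to compound 2 (1.30 log units; beyond the scatter), shows how far the two lie apart when methoxy replaces (4-hydroxycyclohexyl)amino on a carbonyl carbon.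

Compound 3, `CC(C)CNC(=O)c1c(N)sc(-c2ccc(Cl)cc2)c1-c1ccc(Cl)cc1`, has not been measured. It differs from compound 2 by isobutylamino in place of methoxy on a carbonyl carbon. Among the measured compounds shown here, only one measured step bears on this change: the step from compound 1 to compound 2, which was large and went upward when an amino substituent on the carbonyl carbon gave way to methoxy. Compound 3 moves the other way, restoring an amino substituent at that carbon, though isobutylamino is not (4-hydroxycyclohexyl)amino. A step downward beyond the scatter in this assay is therefore expected for compound 3, written as an 8.4-fold lower number from compound 2 to compound 3 (0.92 log units; beyond the scatter), but a full return to the number of compound 1 is not assumed. Compound 3 is estimated at 600 nM, with a likely range of 150 nM to 2500 nM.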

Compound 3, half-maximal inhibitory concentration: 21000 nM
Estimate against measurement, compound 3: 35-fold (1.54 log units) below; measured number outside the range, above it.
By their numbers in this assay, from the lowest: compound 1; then compound 2; then compound 3.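

Isobutylamino in place of methoxy gives a 4.2-fold higher number from compound 2 to compound 3 (0.62 log units; beyond the scatter) in this assay and thus shows that a nitrogen substituent on this carbonyl carbon does not by itself bring the number down, as compound 2 now lies between the two amide compounds, compound 1 and compound 3. With the amide-type nitrogen kept and only its substituent changed, isobutyl in place of 4-hydroxycyclohexyl gives an 84-fold higher number from compound 1 to compound 3 (1.92 log units; beyond the scatter) and so places the low number of compound 1 with the 4-hydroxycyclohexyl group and not with the amide nitrogen alone. Nothing available here accounts for why the isobutylamino compound stands above the methoxy compound.

The compounds shown leave open whether the low number of compound 1 depends on the hydroxy group of its 4-hydroxycyclohexyl or on the ring alone, a question that a plain cyclohexyl group on the amide-type nitrogen would address. They also leave open how a carboxylic acid, or a straight butyl chain on the amide-type nitrogen, would stand against the methoxy of compound 2.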